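Shortening the side chain of compound 2

The source may report more compounds than this note shows. Statements on the series, on what has been measured and on what is new or still open speak of the compounds shown alone.

Measured so far in a functional assay on Caco-2 cells (Homo sapiens) for antiproliferative activity, read by MTT assay, with a stated time of 48 h (a lower number here means a stronger inhibitor, a higher number a weaker inhibitor), for each compound:
Compound 1 `CCn1c(C(=O)N(C)CC(=O)O)ccc1C(CC)(CC)c1ccc(OCCC(O)(CC)CC)c(C)c1` gives 2740 nM as a number
Compound 2 `CCC(C)C(CO)NC(=O)c1ccc(C(CC)(CC)c2ccc(OCCC(O)(CC)CC)c(C)c2)n1CC` gives > 50000 nM as a limit

Compound 2 stands at the limit of > 50000 nM in this assay, at which 1 of the 2 values shown sits, and so gives no number. Compound 3 `CCn1c(C(=O)NC(C)CO)ccc1C(CC)(CC)c1ccc(OCCC(O)(CC)CC)c(C)c1` is not yet measured and puts methyl in place of sec-butyl on a saturated chain carbon bound to an amide-type nitrogen and a saturated chain carbon. Among the compounds with values here, the one measured step that bears on this is large and beyond the scatter, an at least 18-fold higher number from compound 1 to compound 2 (1.26 log units; beyond the scatter) and it exchanged the whole group on the carbonyl carbon, so it guides only loosely. A lower number is expected, with the value staying on the weak side of compound 1 at 2740 nM in this series. The expected step is an at least 2.5-fold lower number from compound 2 to compound 3 (0.39 log units; beyond the scatter) as an estimate against a limit. For compound 3 the estimate is 20000 nM with an expected range from 6000 nM to 50000 nM in this assay for now.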

Compound 3, half-maximal inhibitory concentration: > 50000 nM
Compound 3 was reported as a limit; the forecaster's own chance of this, stated with the estimate: 35%; at least 2.5-fold (0.39 log units) between middle value and limit.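

In this assay compound 3 gives > 50000 nM, a limit and not a number. Exchanging (carboxymethyl)(methyl)amino for (1-(hydroxymethyl)ethyl)amino on the carbonyl carbon gives an at least 18-fold higher number from compound 1 to compound 3 (1.26 log units; beyond the scatter), so the loss seen with compound 2 does not depend on sec-butyl alone. The step from sec-butyl to methyl cannot be read, with both compounds resting on one limit: the limit of > 50000 nM in this assay, at which 2 of the 3 values shown sit.

Which part of (carboxymethyl)(methyl)amino separates compound 1 from compound 2 and compound 3 stays open. Also open, going by these compounds, is whether a side chain ending in an amine, or a longer chain ending in a carboxylic acid, would give a readable number.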